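The source may hold more compounds than are shown below. What is called first, only, known or untested is meant among the compounds shown, and "the series" means these compounds.

Series note. Going by the values given here, compound 1 `CC(C)=CCC1=C(OCc2cn(Cc3ccccn3)nn2)C(=O)c2ccccc2C1=O` is assessed in an ADME assay on HepG2 cells (Homo sapiens) for cytotoxicity, read by MTT assay, with a stated time of 24 h; a higher number here means that more compound is tolerated, a lower number that less compound is tolerated; compound 1 gives 658000 nM, the highest of the two numbers so far. Compound 2 `CC(C)=CCC1=C(OCc2cn(-c3ccc([N+](=O)[O-])cc3)nn2)C(=O)c2ccccc2C1=O` gives 540000 nM in this assay. Among the compounds with values here, the one measured step, a 1.2-fold lower number from compound 1 to compound 2 (0.09 log units; within the scatter), shows that exchanging the (pyridin-2-yl)methyl on the aromatic nitrogen for 4-nitrophenyl leaves the read-out unchanged within the scatter.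

Compound 3 `COc1cc([N+](=O)[O-])ccc1-n1cc(COC2=C(CC=C(C)C)C(=O)c3ccccc3C2=O)nn1` carries the change (2-methoxy-4-nitrophenyl in place of (pyridin-2-yl)methyl on an aromatic nitrogen). Within the data shown here, the only step that bears on it is the one from compound 1 to compound 2, which introduced 4-nitrophenyl at the same aromatic nitrogen and stayed within the scatter; compound 3 adds only a methoxy to that same group, and no measured pair speaks to a methoxy. The expected step is therefore a 1.3-fold lower number from compound 1 to compound 3 (0.10 log units; within the scatter), no movement beyond the scatter. For compound 3 the estimate in this assay is 520000 nM, with a range from 250000 nM to 1000000 nM.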

Compound 3, half-maximal cytotoxic concentration: 701000 nM
Compound 3: middle estimate off by 1.3-fold (0.13 log units), on the low side, and the stated range covers the measured number.
By their numbers in this assay, from the lowest: compounds 2, 1 and 3 (each within the scatter of the next).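

In this assay the methoxy on the aromatic carbon now has a measured pair of its own: a 1.3-fold higher number from compound 2 to compound 3 (0.11 log units; within the scatter) is the step, so this group adds no movement beyond the scatter to the 4-nitrophenyl. The whole exchange of (pyridin-2-yl)methyl for 2-methoxy-4-nitrophenyl on the aromatic nitrogen gives a 1.1-fold higher number from compound 1 to compound 3 (0.03 log units; within the scatter) as its step, so compounds 1, 2 and 3 do not separate at this position, even with the larger group in place. Nothing measured here explains this flat picture.

On these data alone, whether any group on this aromatic nitrogen can move the number beyond the scatter remains open. All three groups shown contain a six-membered aromatic ring, and an amine, a carboxylic acid or a longer chain at this nitrogen is not among them.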